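The source may report more compounds than this note shows. Statements on the series, on what has been measured and on what is new or still open speak of the compounds shown alone.

Compound 1 `O=C(c1ccc(OCCCN2CC[C@H](NS(=O)(=O)c3cccc(F)c3)C2)cc1)C1CC1` is the reference point of this account. In an assay on isolated protein for binding affinity to histamine H2 receptor (Homo sapiens) (on this read-out higher numbers stand for weaker inhibition and lower numbers for stronger inhibition), compound 1 gives 1600 nM, the lowest of the three numbers recorded. Compound 3 `CC(=O)c1ccc(OCCCN2CC[C@H](NC(=O)c3csc(-c4cccnc4)n3)C2)cc1` gives 6200 nM, and compound 2 `CC(=O)c1ccc(OCCCN2CC[C@H](NC(=O)[C@@H](N)CO)C2)cc1` gives 22000 nM; both stand above compound 1 by more than the usual scatter, so compound 1 shows the strongest binding of the three. No pair of these compounds differs in only one place, so no single-point step is available to guide what follows.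

Compound 4 `O=C(c1ccc(OCCCN2CC[C@H](NS(=O)(=O)c3ccccc3)C2)cc1)C1CC1` has not yet been measured. It differs from compound 1 by hydrogen in place of fluoro on an aromatic carbon. Among the compounds with values here, nothing among the measured compounds tests such a change on the shared core, so the expectation rests on the size of the change alone. The change removes one heavy atom and nothing else; the step of a 1.4-fold higher number from compound 1 to compound 4 (0.14 log units; within the scatter) is expected to stay within the usual scatter, with, if anything, a slight drift toward a higher number. Compound 4 is therefore estimated at 2200 nM, with a range from 900 nM to 5500 nM.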

Compound 4, inhibition constant: 1200 nM
For compound 4 the middle estimate is 1.8-fold (0.26 log units) above the measured one; the measured number falls inside the stated range.
By their numbers in this assay, from the lowest: compounds 4 and 1 (each within the scatter of the next); then compound 3; then compound 2.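

In this assay, within the data shown here, the change from 3-fluorophenyl to phenyl gives a 1.3-fold lower number from compound 1 to compound 4 (0.12 log units; within the scatter), the first comparison on this core that differs in one place only. At this aromatic carbon, fluoro and hydrogen therefore cannot be told apart within the scatter, so the fluoro is not required for the binding seen with compound 1. No accompanying measurement bears on why the two compounds read alike.

From the compounds shown here alone, whether this position accepts anything larger remains open, since a chloro, methoxy or trifluoromethyl group, or an amine, at the same carbon might read quite differently from fluoro and hydrogen. Going by these compounds, it is also open how the shared core would respond if a benzoyl group took the place of the whole phenylsulfonyl group.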